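This account rests on a few compounds, and the source may have more. Where it says the series, first, only, none or still open, it means among the compounds named here.

Compound 2 `Oc1nc(-c2cccc(F)c2)sc1-c1nn[nH]n1` stands at the limit of an assay on HEK293 cells for inhibition of transient receptor potential cation channel subfamily M member 8 (Homo sapiens), read by FLIPR, with stated times of 5 min and 3 min; a higher number here means a weaker inhibitor, a lower number a stronger inhibitor: in this assay compound 2 gives > 100000 nM, which is a limit of the assay and not a number. Compound 1 `CCOC(=O)c1ccc(-c2cccc(F)c2)cc1O` likewise gives only a limit in this assay, > 100000 nM. Among the measured compounds shown here, the single numbered value belongs to compound 3 `CCOC(=O)c1sc(-c2ccc(Cl)cc2)nc1O`, which carries an ethyl ester and a chlorophenyl group and gives 550 nM in this assay. For the measured compounds named here, that leaves the limit of > 100000 nM in this assay, at which 2 of the 3 values shown sit, as the main thing known about compound 2, and no step between measured compounds that differ in a single place is available to calibrate a change. Compound 4 `Cc1nc(-c2sc(-c3cccc(F)c3)nc2O)no1` differs from compound 2 in one place: 5-methyl-1,2,4-oxadiazol-3-yl in place of 2H-tetrazol-5-yl on an aromatic carbon. Whether the oxadiazolyl of compound 4 behaves more like the tetrazolyl of compound 2 or more like the ester of compound 3 cannot be read from three values, two of which are limits. The step from compound 2 to compound 4 is nevertheless expected to be a gain beyond the scatter, an at least 20-fold lower number from compound 2 to compound 4 (1.30 log units; beyond the scatter), though with wide uncertainty. Compound 4 is accordingly estimated at 5000 nM, within a range from 500 nM to 60000 nM.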

Compound 4, half-maximal inhibitory concentration: 1800 nM
Estimate against measurement, compound 4: 2.8-fold (0.44 log units) above; the range from low to high includes it.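

In this assay, among the compounds shown here, placing 5-methyl-1,2,4-oxadiazol-3-yl instead of 2H-tetrazol-5-yl on the aromatic carbon next to the ring sulfur gives an at least 55-fold lower number from compound 2 to compound 4 (1.74 log units; beyond the scatter) as the first step that differs in a single place. The change at this one position is therefore enough, on this core, to separate a compound that stays at the limit of the assay from one with a measured number. The value of compound 2 is a limit and not a number, so the step gives a bound and not an exact size: the limit of > 100000 nM in this assay, at which 2 of the 4 values shown sit.

The compounds shown leave open which difference between the two groups goes with the step, as the hydrogen-bond donor, the methyl group and the hetero atoms of the ring all change at once. Also open, on these data alone, is how a carboxylic acid, a primary amide or a nitrile at this position would read in this assay, and whether the step holds with the chlorophenyl group of compound 3 in place of the fluorophenyl group.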